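Removing a tert-butoxycarbonyl group from a ring amine

The compounds below may be only part of what the source reports. "The series", "measured", "known", "first", "only" and "open" are said of these compounds alone.

Of the compounds shown here, three share a common backbone and have been tested in an ADME assay for metabolic stability, in the presence of a further agent that is not named here; a higher number here means that the compound lasts longer, a lower number that the compound disappears faster. Compound 1, `CCOC(=O)/C=C/[C@H](CC(C)C)NC(=O)[C@H](CC(C)C)NC(=O)[C@H](CC(C)C)NC(=O)OCc1ccccc1`, reaches the limit of the method, giving > 6 h. Compound 2, `CCOC(=O)/C=C/[C@H](CC(C)C)NC(=O)[C@H](CO)NC(=O)[C@@H](NC(=O)OCc1ccccc1)C(C)C`, also sits at that limit, with > 6 h. Compound 3, `CCOC(=O)/C=C/[C@H](CC(C)C)NC(=O)[C@H](CO)NC(=O)[C@@H](NC(=O)C1=CCCN(C(=O)OC(C)(C)C)C1)C(C)C`, likewise gives only the limit, > 6 h. So compound 3 stands where the other two stand, and no number separates any of them: all three values rest at the limit of > 6 h in this assay, at which 3 of the 3 values shown sit.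

The next compound, compound 4, is `CCOC(=O)/C=C/[C@H](CC(C)C)NC(=O)[C@H](CO)NC(=O)[C@@H](NC(=O)C1=CCCNC1)C(C)C`. Compared with compound 3 the change is hydrogen in place of tert-butoxycarbonyl on an amine nitrogen in a ring. Within the data shown here, no pair of measured compounds differs in this way, so no measured step guides the expectation. Since compound 3 gives only a limit in this assay, the step from compound 3 to compound 4 is expected to be a number no higher from compound 3 to compound 4 (the limit leaves the size open), with no clear direction beyond the scatter. Compound 4 is therefore expected to give about 6 h in this assay, somewhere between 2 h and 12 h, and quite possibly again only a limit.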

Compound 4, half-life: > 6 h
Compound 4: a limit, no number; the forecaster's own chance of this, stated with the estimate: 55%; the middle value lies on the limit itself.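

In this assay compound 4 gives > 6 h, which is a limit and not a number. The steps from compound 2 and compound 3 to compound 4 cannot be read, as every value rests at the same point: the limit of > 6 h in this assay, at which 4 of the 4 values shown sit.

The compounds shown leave open how long each one actually lasts, and whether hydrogen in place of tert-butoxycarbonyl changes that at all.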